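A few compounds are considered here, and "the series" means these few. Any claim that something is new, unique, unknown or untested is made for them only; others in the source may bear on it.

Three sulfamates with a shared core differ only in the amino group on one aromatic carbon. In an assay on HEK293 cells for inhibition of Steryl-sulfatase (Homo sapiens), tested at 1 uM (on this read-out higher numbers stand for a stronger effect at the one concentration tested and lower numbers for a weaker effect), compound 1 `CN(CCCN1CCCCC1)c1cccc(C(=O)N2CCc3ccc(OS(N)(=O)=O)cc3C2)c1` gives 30.6%. Compound 2 `CC(C)CCN(CCC(C)C)c1cccc(C(=O)N2CCc3ccc(OS(N)(=O)=O)cc3C2)c1` gives 75.9% in this assay. Compound 3 `CCN(Cc1cccc(Br)c1)c1cccc(C(=O)N2CCc3ccc(OS(N)(=O)=O)cc3C2)c1` gives 24.9% in this assay; on the numbers shown it sits at the bottom, yet its gap to compound 1 lies within the scatter and only the gap to compound 2 lies beyond it. The steps into compound 3 are a number 5.7 percentage points lower from compound 1 to compound 3 (within the scatter) and a number 51 percentage points lower from compound 2 to compound 3 (beyond the scatter). Compound 4 `NS(=O)(=O)Oc1ccc2c(c1)CN(C(=O)c1cccc(N3CCc4ccccc4C3)c1)CC2` is the next member, still to be measured: 1,2,3,4-tetrahydroisoquinolin-2-yl in place of (3-bromobenzyl)(ethyl)amino on an aromatic carbon. Among the compounds with values here, no measured step covers this exchange. Both groups carrying an aromatic ring or a second ring nitrogen, in compound 1 and compound 3, gave the lower values, whereas only compound 2 with diisopentylamino reached the higher one, so no step beyond the scatter is expected from compound 3. The expected step is a number 5.1 percentage points higher from compound 3 to compound 4 (within the scatter). Compound 4 is therefore estimated at 30% in this assay, with a range from 10% to 55%.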

Compound 4, a percentage reported as inhibition, at one concentration (the size of the read-out at that concentration, not a potency): 50.2%
Compound 4: the middle estimate sits 20.2 percentage points below what was measured, within the range that was stated.
By their numbers in this assay, from the lowest: compounds 3 and 1 (each within the scatter of the next); then compound 4; then compound 2.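

In this assay, 1,2,3,4-tetrahydroisoquinolin-2-yl gives a number 25.3 percentage points higher from compound 3 to compound 4 (beyond the scatter) and a number 19.6 percentage points higher from compound 1 to compound 4 (beyond the scatter), so a six-membered aromatic ring of carbon only, present in both the leaving and the entering group, does not by itself hold this position at the level of compound 3. The exchange for diisopentylamino still gives a number 25.7 percentage points lower from compound 2 to compound 4 (beyond the scatter), which separates the amino groups at this position into three levels: compounds 1 and 3 together, then compound 4, then compound 2. No supporting data explain these differences.

The change from compound 3 to compound 4 removes the bromine and adds the non-aromatic ring together, leaving their contributions unseparated; a benzyl(ethyl)amino group without bromine would address this. As far as these compounds go, how a smaller ring such as morpholin-4-yl compares with these groups also remains open.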